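A few compounds are considered here, and "the series" means these few. Any claim that something is new, unique, unknown or untested is made for them only; others in the source may bear on it.

Three compounds share one core and differ only in the outer ring attached to it. In a functional assay on SNB-19 cells (Homo sapiens) for inhibition, read by sulforhodamine B assay, with a stated time of 48 h, tested at 10 uM (on this read-out lower numbers stand for less inhibition and higher numbers for more inhibition at the one concentration tested (going by the name of the read-out)), compound 1 `COc1ccc(-c2cn3ccnc3c(-c3ccc4ncn(C5CCCCC5)c4c3)n2)cc1` gives 68.4%. Compound 2 `Fc1ccc(-c2cn3ccnc3c(-c3ccc4ncn(C5CCCCC5)c4c3)n2)cc1` carries the change fluoro in place of methoxy on an aromatic carbon and gives 14.2%, a step of a number 54.2 percentage points lower from compound 1 to compound 2 (beyond the scatter). Compound 3 `COc1ccccc1-c1cn2ccnc2c(-c2ccc3ncn(C4CCCCC4)c3c2)n1` differs from compound 1 by 2-methoxyphenyl in place of 4-methoxyphenyl on an aromatic carbon. Compound 3 gives 11.1%, a step of a number 57.3 percentage points lower from compound 1 to compound 3 (beyond the scatter); against compound 2 it shows a number 3.1 percentage points lower from compound 2 to compound 3 (within the scatter). Compound 4 `Fc1ccccc1-c1cn2ccnc2c(-c2ccc3ncn(C4CCCCC4)c3c2)n1` awaits measurement in this assay; it arises from compound 3 by fluoro in place of methoxy on an aromatic carbon, the same kind of change as from compound 1 to compound 2, though there the group sat para to a large group and here it sits ortho to a large group. Because compound 3 already gives 11.1%, little room for a further fall remains, so the step is expected to be small, a number 2.1 percentage points lower from compound 3 to compound 4 (within the scatter), unlike the earlier one. Compound 4 is estimated at 9%, between 0% and 25%.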

Compound 4, a percentage reported as inhibition, at one concentration (the size of the read-out at that concentration, not a potency): 7.56%
For compound 4 the middle estimate is 1.4 percentage points above the measured one; the measured number falls inside the stated range.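

The swap of methoxy for fluoro gives a number 3.5 percentage points lower from compound 3 to compound 4 (within the scatter), so in this assay the change does not carry over with the same size from one core to the other: the same change on two cores in this assay, a number 54.2 percentage points lower (beyond the scatter) from compound 1 to compound 2 and a number 3.5 percentage points lower (within the scatter) from compound 3 to compound 4, 50.7 percentage points apart, beyond the scatter of two such steps

Compound 4 also shows a number 6.6 percentage points lower from compound 2 to compound 4 (within the scatter) and a number 60.8 percentage points lower from compound 1 to compound 4 (beyond the scatter), so among these four compounds only compound 1 stands apart. What this does not show is why the two steps differ, or how the same change would behave on any other core.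

From the compounds shown here alone, it stays open whether the high value of compound 1 belongs to methoxy alone, or whether an ethoxy group or a dimethylamino group in that same place on the outer ring would keep it.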